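This account rests on a few compounds, and the source may have more. Where it says the series, first, only, none or still open, it means among the compounds named here.

Compound 1 `C=CC[N+](C)(C)c1cccc(O)c1` and compound 2 `C=CC[N+](C)(C)c1cccc(OC)c1` share one core, while compound 3 `C=C(C)C[N+](C)(C)c1ccccc1O` and compound 4 `C=C(C)C[N+](C)(C)c1ccccc1OC` share another; the difference between the two cores is not broken down here. In a functional assay with Cavia porcellus as the target (a lower number here means a stronger inhibitor, a higher number a weaker inhibitor), compound 1 gives 13000 nM. For compound 2 this assay reports only a limit, > 3000 nM. The change from compound 1 to compound 2 is methyl in place of hydrogen on an oxygen on an aromatic ring, and the step that the limit leaves unreadable from compound 1 to compound 2 stays unreadable because of the limit of > 3000 nM in this assay, at which 2 of the 3 values shown sit. For compound 3 this assay likewise reports only a limit, > 3000 nM. Compound 4 differs from compound 3 by the same kind of change, (methyl in place of hydrogen on an oxygen on an aromatic ring), at a place described in the same words. Since compound 1 gives 13000 nM, compound 4 is expected to remain weak, with an estimated step that the limit leaves unreadable from compound 3 to compound 4. Compound 4 is estimated at 20000 nM, between 5000 nM and 100000 nM.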

Compound 4, half-maximal inhibitory concentration: > 3000 nM
Compound 4 gave a limit, no number; the forecaster's own chance of this, stated with the estimate: 80%; the middle value does not contradict the limit.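

The step from compound 3 to compound 4 cannot be read in this assay, because compound 3 and compound 4 are each reported only as a limit: the limit of > 3000 nM in this assay, at which 3 of the 4 values shown sit.

The compounds shown leave open whether the change from hydroxy to methoxy alters potency in this assay on either core.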